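This account rests on a few compounds, and the source may have more. Where it says the series, first, only, none or still open, it means among the compounds named here.

Values in a functional assay for inhibition, with Rattus norvegicus as the target; a lower number here means a stronger inhibitor, a higher number a weaker inhibitor:
- Compound 1 `CC(C)(C)CN/C(=C\[N+](=O)[O-])Nc1cccnc1`: 1000 nM
- Compound 2 `CC(N/C(=C\[N+](=O)[O-])Nc1cccnc1)C(C)(C)C`: 31.6 nM
- Compound 3 `C[C@@H](N/C(=C\[N+](=O)[O-])Nc1cccnc1)C(C)(C)C`: 10 nM; 1000 nM (2 entries)

Compound 2 holds the lower of the two single numbers. Compound 3 offers no single number to compare, given the several entries of compound 3 in this assay, 10 nM; 1000 nM (2 entries) and (the fact that one of compounds 2 and 3 is drawn with a defined configuration and the other without, at the place where they differ). Compound 4 `O=[N+]([O-])/C=C(/Nc1cccnc1)NC1CCCCC1` has cyclohexyl in place of 1,2,2-trimethylpropyl on an amine nitrogen. Within the data shown here, the one measured step that bears on this change is a 32-fold lower number from compound 1 to compound 2 (1.50 log units; beyond the scatter), a large step made in the same group on that nitrogen. It shows that this group can move the number strongly, so a moderate rise is expected rather than a match with compound 2. The expected change is a 3.2-fold higher number from compound 2 to compound 4 (0.50 log units; beyond the scatter). For compound 4 the estimate is 100 nM, with an expected range from 20 nM to 500 nM.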

Compound 4, half-maximal inhibitory concentration: 3160 nM
For compound 4 the middle estimate is 32-fold (1.50 log units) below the measured one, and the stated range ends below it.
By their numbers in this assay, from the lowest: compound 2; then compound 1; then compound 4.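

On the amine nitrogen, cyclohexyl in place of 1,2,2-trimethylpropyl gives a 100-fold higher number from compound 2 to compound 4 (2.00 log units; beyond the scatter), so a group with the same six carbons, closed into a ring, does not match the branched chain in this assay. Cyclohexyl in place of neopentyl gives a 3.2-fold higher number from compound 1 to compound 4 (0.50 log units; beyond the scatter), which leaves compound 4 with the highest number of the three compounds with single values. Nothing shown here accounts for this loss.

From the compounds shown here alone, whether cyclopentyl or phenyl on that nitrogen would fall nearer compound 2 or compound 4 stays open. Going by these compounds, the standing of compound 3 also stays open: the several entries of compound 3 in this assay, 10 nM; 1000 nM (2 entries).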